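The source may hold more compounds than are shown below. What is called first, only, known or untested is meant among the compounds shown, and "the series" means these compounds.

In an ADME assay on the whole organism with Oryza sativa as the target, tested at 10 uM (a higher number here means a weaker effect of the compound at the concentration tested, a lower number a stronger effect), three compounds have been measured: compound 1 `C[C@H](NC(=O)Nc1ccccc1F)c1ccccc1` gives 65%, compound 2 `C[C@H](NC(=O)Nc1ccc(F)cc1F)c1ccccc1` gives 99%, and compound 3 `Cc1ccc(NC(=O)N[C@H](C)c2ccccc2)c(F)c1` gives 99%.

Compound 3 stands level with compound 2 at the digits shown, the two together the highest of the three numbers, while compound 1 sits lower by a margin beyond the scatter. Going by the values given here, the only measured step, a number 34 percentage points higher from compound 1 to compound 2 (beyond the scatter), concerns an aromatic substituent and says nothing about configuration.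

Among the compounds with values here, compound 4 `Cc1ccc(NC(=O)N[C@@H](C)c2ccccc2)c(F)c1` differs from compound 3 as follows. the two compounds have the same atoms and bonds and differ only in configuration as drawn: 1 of 1 stereo elements differ; a stereocentre at a saturated chain carbon is drawn R in compound 3 and S in compound 4 No measured step bears on such a change, so its size is unknown. The author expects a moderate drop for compound 4, a number 11 percentage points lower from compound 3 to compound 4 (beyond the scatter), and estimates 88%, within 50% to 100%.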

Compound 4, a percentage reported as activity, at one concentration (the size of the read-out at that concentration, not a potency): 100%
Compound 4: the middle estimate sits 12 percentage points below what was measured; the measured number falls inside the stated range.
By their numbers in this assay, from the lowest: compound 1; then compounds 2, 3 and 4 (each within the scatter of the next).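

Inverting the stereocentre at the saturated chain carbon, from R to S, gives a number 1 percentage points higher from compound 3 to compound 4 (within the scatter) in this assay, so at this position and with this substitution the configuration as drawn leaves no readable mark, and the comparison is a clean one: the fact that compounds 3 and 4 differ only in the configuration as drawn

Methyl in place of fluoro on an aromatic carbon gives a number 1 percentage points higher from compound 2 to compound 4 (within the scatter), whereas a methyl group on an aromatic carbon that carried no fluoro gives a number 35 percentage points higher from compound 1 to compound 4 (beyond the scatter).

As far as these compounds go, whether configuration counts equally with the substitution of compound 1 stays open. So does the outcome with a chloro or methoxy group on an aromatic carbon.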